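From pyridin-3-yl to pyridin-4-yl on the amine nitrogen

The source may hold more compounds than are shown below. What is called first, only, known or untested is meant among the compounds shown, and "the series" means these compounds.

In a functional assay on VCaP cells (Homo sapiens) for antiproliferative activity, read by CCK-8 assay, with a stated time of 6 days (a lower number here means a stronger inhibitor, a higher number a weaker inhibitor), compound 1 `C[C@@H](Cn1ccc(-c2ccc(C#N)c(Cl)c2)n1)NS(=O)(=O)c1cn(C)cn1`, with (1-methyl-1H-imidazol-4-yl)sulfonyl on its amine nitrogen, gives 13600 nM. Compound 2 `C[C@@H](Cn1ccc(-c2ccc(C#N)c(Cl)c2)n1)Nc1ccccc1`, with phenyl in that place, reads > 30000 nM, which is a limit of the assay and not a number. Compound 3 `C[C@@H](Cn1ccc(-c2ccc(C#N)c(Cl)c2)n1)Nc1cccnc1`, with pyridin-3-yl there, reads > 30000 nM, again a limit. Compound 3 therefore has no exact value and stands at the limit of > 30000 nM in this assay, at which 2 of the 3 values shown sit.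

Two measured steps lead to this limit: an at least 2.2-fold higher number from compound 1 to compound 2 (0.34 log units; beyond the scatter) and an at least 2.2-fold higher number from compound 1 to compound 3 (0.34 log units; beyond the scatter). Both concern loss of the sulfonyl group, not a change within the aromatic ring. The step closest to the new change is a step that the two limits leave unreadable from compound 2 to compound 3, and it gives no size.

Compound 4 `C[C@@H](Cn1ccc(-c2ccc(C#N)c(Cl)c2)n1)Nc1ccncc1` differs from compound 3 as follows: pyridin-4-yl in place of pyridin-3-yl on an amine nitrogen. Among the measured compounds shown here, with a step that the two limits leave unreadable from compound 2 to compound 3 as the only comparison between such rings, no step beyond the scatter is expected in this assay, and no direction can be favoured. The step expected is a number no higher from compound 3 to compound 4 (the limit leaves the size open). For compound 4 the estimated value is 30000 nM, with an expected range from 12000 nM to 60000 nM, and a report as a limit is likely.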

Compound 4, half-maximal inhibitory concentration: 9900 nM
Compound 4: the middle estimate sits 3.0-fold (0.48 log units) above what was measured; the measured number lies below the stated range.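

In this assay, the amine nitrogen turns out to respond to which pyridine ring it carries: pyridin-4-yl in place of pyridin-3-yl gives an at least 3.0-fold lower number from compound 3 to compound 4 (0.48 log units; beyond the scatter), although the two groups hold the same atoms, joined differently. Pyridin-4-yl in place of phenyl gives an at least 3.0-fold lower number from compound 2 to compound 4 (0.48 log units; beyond the scatter), so pyridin-4-yl is the only one of the three aromatic rings shown on this nitrogen to give an exact value, and the true size of both steps stays open: the limit of > 30000 nM in this assay, at which 2 of the 4 values shown sit. Set against the sulfonyl group, pyridin-4-yl gives a 1.4-fold lower number from compound 1 to compound 4 (0.14 log units; within the scatter), which means that the loss seen earlier on leaving the (1-methyl-1H-imidazol-4-yl)sulfonyl group does not hold for every aromatic ring on this nitrogen.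

The step from compound 2 to compound 3 still cannot be read, so nothing here tells whether pyridin-3-yl and phenyl differ at all. The compounds shown also leave open how pyridin-2-yl, a pyridin-4-yl ring bearing a methyl group, or a saturated ring such as piperidin-4-yl would read on this nitrogen.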